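Removing one chloro from the purine of compound 2

This account rests on a few compounds, and the source may have more. Where it says the series, first, only, none or still open, it means among the compounds named here.

Measured so far:
- compound 1 `ClCc1ccc(Cn2cnc3c(Cl)ncnc32)cc1` — in a functional assay on NCI-H522 cells (Homo sapiens) for cytotoxicity, read by sulforhodamine B assay, with a stated time of 48 h (on this read-out higher numbers stand for lower toxicity in this test and lower numbers for higher toxicity in this test), compound 1 sits at the limit > 100000 nM, which is a limit of the assay and not a number.
- compound 2 `ClCc1ccccc1Cn1cnc2c(Cl)nc(Cl)nc21` — in this assay compound 2 gives 6760 nM.

Going by the values given here, compound 2 is the only compound in this assay with an actual number; the other entry is a limit (the limit of > 100000 nM in this assay, at which 1 of the 2 values shown sits). Compound 3 `ClCc1ccccc1Cn1cnc2c(Cl)ncnc21` has not yet been measured. It differs from compound 2 in one place: hydrogen in place of chloro on an aromatic carbon, a hydrogen in place of chloro on an aromatic carbon. Among the compounds with values here, no measured pair differs only in this way, so the size of the step rests on judgement alone. The expectation is a loss of potency beyond the usual scatter, with a fair chance that only a limit is reported. For compound 3 the estimate in this assay is 30000 nM (range 7000 nM to 120000 nM), meaning an expected step of a 4.4-fold higher number from compound 2 to compound 3 (0.65 log units; beyond the scatter).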

Compound 3, concentration lethal to 50% of the cells: > 100000 nM
Compound 3 ended at the assay's limit (the forecaster's own chance of this, stated with the estimate: 40%); at least 3.3-fold (0.52 log units) between middle value and limit.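

In this assay, the chloro on the aromatic carbon between two ring nitrogen atoms carries weight: hydrogen in its place gives an at least 14-fold higher number from compound 2 to compound 3 (1.17 log units; beyond the scatter). This is the first comparison in the series between compounds that differ in one place, and that single change separates the one measured value from the assay's limit: the limit of > 100000 nM in this assay, at which 2 of the 3 values shown sit.

Compound 3 stands at a limit and not at a number, so the step gives only a lower bound on the change and its full size cannot be read. Going by these compounds, whether chloro itself is needed at this carbon remains open, since an amine, a methoxy group or a fluoro there could keep, lose or exceed the value of compound 2. The compounds shown also cannot say whether the same change would act alike with the rest of the structure altered.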